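Methoxyphenyl in place of phenyl on the core of compound 2

The source may report more compounds than this note shows. Statements on the series, on what has been measured and on what is new or still open speak of the compounds shown alone.

Two regioisomeric members of the series have been tested so far. Compound 1 `COc1ccc(-c2cc(C(C)=O)c3[nH]c(-c4ccccc4)cc3c2)cc1` gives 47800 nM in a functional assay on MCF7 cells (Homo sapiens) for cytotoxicity, read by MTT assay, with a stated time of 2 days; on this read-out lower numbers stand for higher toxicity in this test and higher numbers for lower toxicity in this test. Compound 2 `COc1ccc(-c2cc3cc(-c4ccccc4)cc(C(C)=O)c3[nH]2)cc1` gives > 100000 nM in this assay, and that figure is a limit of the test rather than a number. Compound 2 thus stands at the weak end of the two values shown, sitting at the limit of > 100000 nM in this assay, at which 1 of the 2 values shown sits, while compound 1 has a measured value in this assay. Compound 3 `COc1ccc(-c2cc(C(C)=O)c3[nH]c(-c4ccc(OC)cc4)cc3c2)cc1` is the next member to be measured. Relative to compound 2 it carries methoxy in place of hydrogen on an aromatic carbon, that is methoxy in place of hydrogen on an aromatic carbon. Among the compounds with values here, no measured pair isolates this change, so no step size can be read from the data, and because compound 2 sits at the limit of > 100000 nM in this assay, at which 1 of the 2 values shown sits, its own value gives no direction either. The expected step is an at least 1.1-fold lower number from compound 2 to compound 3 (0.04 log units; that floor lies within the scatter), which is within the scatter, with a modest lean toward higher toxicity at most. Compound 3 is therefore estimated at 90000 nM, with a range from 30000 nM to 300000 nM. A limit rather than a number remains a likely outcome for compound 3.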

Compound 3, concentration lethal to 50% of the cells: 25200 nM
Compound 3: middle estimate off by 3.6-fold (0.55 log units), on the high side; the whole stated range lies above it.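

In this assay, methoxy in place of hydrogen on an aromatic carbon now has two readable steps ending at compound 3: an at least 3.9-fold lower number from compound 2 to compound 3 (0.59 log units; beyond the scatter), and a 1.9-fold lower number from compound 1 to compound 3 (0.28 log units; within the scatter). Compound 2 gives a limit and not a number, so the first step has only a floor and its true size stays unknown: the limit of > 100000 nM in this assay, at which 1 of the 3 values shown sits.

Within the data shown here, the comparison with compound 1 is the only one between two numbers, and there the change from phenyl to 4-methoxyphenyl does not separate the compounds, so the step beyond the scatter appears only on the side of compound 2.

The compounds shown leave open whether the same change gives a step of similar size on other members of the series, since only these two steps exist for it. They also leave open what an amine, a carboxylic acid or a longer chain in place of methoxy, para to a large group, would do to the value in this assay.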